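A few compounds are considered here, and "the series" means these few. Any claim that something is new, unique, unknown or untested is made for them only; others in the source may bear on it.

Measured compounds:
compound 1 `Cc1cc(S(=O)(=O)/N=C(\N)N/N=C/C#Cc2ccccc2)c(SCc2ccccc2C)cc1Cl` gives 13000 nM;
compound 2 `C/C(C#Cc1ccccc1)=N\N/C(N)=N/S(=O)(=O)c1cc(C)c(Cl)cc1SCc1ccc(C)cc1` gives 125000 nM;
compound 3 `Cc1cc(S(=O)(=O)/N=C(\N)N/N=C/C#Cc2ccccc2)c(SCc2ccc(C(F)(F)F)cc2)cc1Cl` gives 105000 nM.

All three were tested in a functional assay on MCF7 cells (Homo sapiens) for antiproliferative activity, read by MTT assay, with a stated time of 72 h; on this read-out higher numbers stand for weaker inhibition and lower numbers for stronger inhibition. Compound 2 carries the highest number of the three; compound 3 stands within the scatter of it, while compound 1 sits far lower. Compound 4 `C/C(C#Cc1ccccc1)=N\N/C(N)=N/S(=O)(=O)c1cc(C)c(Cl)cc1SCc1cccc(Cl)c1` is not yet measured and differs from compound 2 in one place: 3-chlorophenyl in place of 4-methylphenyl on a saturated chain carbon bound to a sulfur.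

Among the compounds with values here, only one measured step alters the aryl group on that same saturated chain carbon bound to a sulfur: an 8.1-fold higher number from compound 1 to compound 3 (0.91 log units; beyond the scatter). Within the data shown here, compound 1 and compound 2 differ in two places at once, so their values show only that a high number already sits with compound 2. An exchange of one aryl ring for another at this carbon therefore shifted the number by a modest amount in the one case seen, and compound 2 begins near the top of the observed range. A step of a 1.2-fold higher number from compound 2 to compound 4 (0.08 log units; within the scatter) is expected, with no clear direction beyond the scatter. Compound 4 is estimated at 150000 nM, within 50000 nM to 450000 nM.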

Compound 4, half-maximal inhibitory concentration: 80000 nM
Compound 4: the middle estimate sits 1.9-fold (0.27 log units) above what was measured, within the range that was stated.
By their numbers in this assay, from the lowest: compound 1; then compounds 4, 3 and 2 (each within the scatter of the next).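

In this assay the step of a 1.6-fold lower number from compound 2 to compound 4 (0.19 log units; within the scatter) stays within the scatter, so 3-chlorophenyl and 4-methylphenyl on a saturated chain carbon bound to a sulfur cannot be told apart on the core of compound 2. The earlier step of an 8.1-fold higher number from compound 1 to compound 3 (0.91 log units; beyond the scatter) lay beyond the scatter on a different core, so exchanging one aryl group for another at this carbon does not always move the number. Nothing measured here accounts for either outcome.

Going by these compounds, whether 2-methylphenyl, the group of compound 1, would bring the number down on the core of compound 2 remains open. Also open, on these data alone, is how this carbon would respond to a ring bearing an amine or a carboxylic acid, or to a longer chain in place of the benzyl group.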